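Replacing the Amide on the Shared Core with an Imine

A few compounds are considered here, and "the series" means these few. Any claim that something is new, unique, unknown or untested is made for them only; others in the source may bear on it.

Measured so far in a functional assay on Ehrlich cells (Mus musculus) for cytotoxicity, read by trypan blue exclusion, with a stated time of 2 h, tested at 25 ug/mL; on this read-out lower numbers stand for a weaker effect and higher numbers for a stronger effect at the one concentration tested:
compound 1, `N#CC1=C(NC(=O)C2CC2)N(c2ccc(S(N)(=O)=O)cc2)C2=C(C(=O)CCC2)C1c1ccc(Cl)cc1Cl`, gives 40%
compound 2, `N#CC1=C(NC(=O)c2ccccc2)N(c2ccc(S(N)(=O)=O)cc2)C2=C(C(=O)CCC2)C1c1ccc(Cl)cc1Cl`, gives 60%
compound 3, `N#CC1=C(NC(=O)c2ccc([N+](=O)[O-])cc2)N(c2ccc(S(N)(=O)=O)cc2)C2=C(C(=O)CCC2)C1c1ccc(Cl)cc1Cl`, gives 40%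

Compound 3 sits level with compound 1, the two together the lowest of the three numbers, as the step of no change at the digits printed from compound 1 to compound 3 (within the scatter) shows, while compound 2 stands higher, the step of a number 20 percentage points lower from compound 2 to compound 3 (beyond the scatter) being the gap between them.

Compound 4, `CCO/C=N/C1=C(C#N)C(c2ccc(Cl)cc2Cl)C2=C(CCCC2=O)N1c1ccc(S(N)(=O)=O)cc1`, differs from compound 3 by a group of 5 heavy atoms (3 carbon, 1 nitrogen, 1 oxygen; no ring) in place of a group of 12 heavy atoms (7 carbon, 2 nitrogen, 3 oxygen; one six-membered aromatic ring of carbon only), on a double-bonded ring carbon. Going by the values given here, none of the measured steps bears directly on this change. Each of them only varies the group on a carbonyl carbon of an amide that stays in place: a number 20 percentage points higher from compound 1 to compound 2 (beyond the scatter), no change at the digits printed from compound 1 to compound 3 (within the scatter) and a number 20 percentage points lower from compound 2 to compound 3 (beyond the scatter), so the whole spread across the three compounds is modest. Here the ((4-nitrophenyl)carbonyl)amino group leaves altogether and a small group with no ring enters, so the measured steps give only a sense of how little this position has moved the read-out so far, not a direction.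

On that basis compound 4 is expected to give about 45%, with a range from 25% to 65%. This estimate means a step of a number 5 percentage points higher from compound 3 to compound 4 (within the scatter), not beyond the scatter.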

Compound 4, a percentage reported as activity, at one concentration (the size of the read-out at that concentration, not a potency): 30%
For compound 4 the middle estimate is 15 percentage points above the measured one; low and high end bracket the measured number.
By their numbers in this assay, from the lowest: compounds 4, 1 and 3 (each within the scatter of the next); then compound 2.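

In this assay, going by these compounds alone, the earlier compounds varied only the group on the amide carbonyl, whereas compound 4 shows what happens when the amide itself goes. Replacing the ((4-nitrophenyl)carbonyl)amino group with a ring-free group that has no hydrogen-bond donor leaves the number within the scatter (a number 10 percentage points lower from compound 3 to compound 4 (within the scatter)), and the same holds against the cyclopropyl amide (a number 10 percentage points lower from compound 1 to compound 4 (within the scatter)), so an amide is not needed at this position for a reading at this level, while only the comparison with the phenyl amide goes beyond the scatter (a number 30 percentage points lower from compound 2 to compound 4 (beyond the scatter)). Nothing available explains why the imine and the amides compare in this way.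

The compounds shown leave open whether a plain amino group on this double-bonded ring carbon, or an imine carrying a longer chain such as hexyloxy, would read at a similar level. They also do not separate the removal of the amide carbonyl from the change in the size of the group, a question that an acetyl amide could help to answer.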